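Swapping a charged ring tail and the collagen promoter read-out

The compounds below may be only part of what the source reports. "The series", "measured", "known", "first", "only" and "open" are said of these compounds alone.

Three compounds sharing one core, each carrying a chain that ends in a ring bearing a net charge, were tested in an assay on LX2 cells for inhibition of COL1A1 promoter (Homo sapiens), read by a luciferase reporter, with a stated time of 24 h, tested at 20 uM; on this read-out higher numbers stand for a stronger effect at the one concentration tested and lower numbers for a weaker effect. Compound 1 `Cc1cc(OCCCCCCC[N+]2(C)CCN(C)CC2)cc(-n2cc(C(=O)Nc3cc(F)cc(F)c3)c(=O)c3ccc(N(C)C)nc32)c1` gives 2.8%. Compound 2 `Cc1ccc(-n2cc(C(=O)Nc3cc(F)cc(F)c3)c(=O)c3ccc(N(C)C)nc32)cc1OCCCCCCC[N+]1(C)CCN(C)CC1`, built from the same atoms joined differently, gives 10.4%; the difference between the two cores is not broken down here, and the two values lie within the usual scatter of each other. Compound 3 `CC[N+]1(CCCCCCCOc2cc(C)cc(-n3cc(C(=O)Nc4cc(F)cc(F)c4)c(=O)c4ccc(N(C)C)nc43)c2)CCCC1` gives 35.1%.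

Compound 3 arises from compound 1 by one change: a group of 7 heavy atoms (6 carbon, 1 nitrogen; one five-membered non-aromatic ring with 1 hetero atom) in place of a group of 8 heavy atoms (6 carbon, 2 nitrogen; one six-membered non-aromatic ring with 2 hetero atoms), on a saturated chain carbon, seven bonds along the chain from an oxygen on an aromatic ring. This step produced a number 32.3 percentage points higher from compound 1 to compound 3 (beyond the scatter), the one clear movement among the three measured values.

Compound 4 `CC[N+]1(CCCCCCCOc2cc(-n3cc(C(=O)Nc4cc(F)cc(F)c4)c(=O)c4ccc(N(C)C)nc43)ccc2C)CCCC1` is not yet measured. It stands to compound 2 as compound 3 stands to compound 1, since the change is the same: a group of 7 heavy atoms (6 carbon, 1 nitrogen; one five-membered non-aromatic ring with 1 hetero atom) in place of a group of 8 heavy atoms (6 carbon, 2 nitrogen; one six-membered non-aromatic ring with 2 hetero atoms), on a saturated chain carbon, seven bonds along the chain from an oxygen on an aromatic ring. The ring is exchanged at the same place, seven bonds along the chain from an oxygen on an aromatic ring, so the change is the same in kind and in position.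

Because the earlier step was a number 32.3 percentage points higher from compound 1 to compound 3 (beyond the scatter), a step of similar size is expected here, namely a number 29.6 percentage points higher from compound 2 to compound 4 (beyond the scatter). This expectation rests on a single measured pair, so the range is kept wide. Compound 4 is therefore estimated to give 40% in this assay, with a likely span from 22% to 58%.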

Compound 4, a percentage reported as inhibition, at one concentration (the size of the read-out at that concentration, not a potency): 57%
Estimate against measurement, compound 4: 17 percentage points below, within the range that was stated.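

In this assay, putting the five-membered ring with one nitrogen on the chain in place of the six-membered ring with two nitrogens gave a number 46.6 percentage points higher from compound 2 to compound 4 (beyond the scatter). The change therefore moves the number the same way on both cores, but its size does not carry over unchanged: the same change on two cores in this assay, a number 32.3 percentage points higher (beyond the scatter) from compound 1 to compound 3 and a number 46.6 percentage points higher (beyond the scatter) from compound 2 to compound 4, 14.3 percentage points apart, beyond the scatter of two such steps

Going by these compounds alone, with only two pairs, this shows that the direction held on these two cores, not that it would hold on a third, and it does not explain why the steps differ in size; each value is also a read-out at one concentration and not a potency.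

The compounds shown leave open which part of the exchange matters, since ring size and the second ring nitrogen change together, and a six-membered piperidine ring with a single nitrogen could help to separate the two. Also open, from the compounds shown here alone, is how a shorter or longer chain, or a simple tertiary amine at the chain end in place of the charged ring, would behave on either core.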